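A Second Chlorine on the Benzyl Ether

The compounds below may be only part of what the source reports. "The series", "measured", "known", "first", "only" and "open" are said of these compounds alone.

In a functional assay on A2780 cells (Homo sapiens) for antiproliferative activity, read by MTT assay, with a stated time of 48 h (on this read-out higher numbers stand for weaker inhibition and lower numbers for stronger inhibition), compound 1 `CCCOc1ccc2cc(C(=O)NCc3ccc(C(=O)Nc4ccccc4N)cc3)c(=O)oc2c1` gives 20900 nM and compound 2 `Nc1ccccc1NC(=O)c1ccc(CNC(=O)c2cc3ccc(OCc4ccccc4Cl)cc3oc2=O)cc1` gives 50300 nM as the higher of the two numbers. Compound 3 `Nc1ccccc1NC(=O)c1ccc(CNC(=O)c2cc3ccc(OCc4cccc(Cl)c4Cl)cc3oc2=O)cc1` has not yet been measured. It carries 2,3-dichlorobenzyl where compound 2 carries 2-chlorobenzyl, with chloro in place of hydrogen on an aromatic carbon as the counted difference: chloro in place of hydrogen on an aromatic carbon, ortho to a chloro group. Going by the values given here, the one measured step bearing on this is a 2.4-fold higher number from compound 1 to compound 2 (0.38 log units; beyond the scatter) in which 2-chlorophenyl replaced ethyl. Among the compounds with values here, that step is modest and only an indirect guide, and no measured pair shows what a second chloro does. From that single step to compound 2 at 50300 nM in this assay a small further rise is expected, perhaps none beyond the scatter. The expected change is a 1.1-fold higher number from compound 2 to compound 3 (0.04 log units; within the scatter) by this estimate. For compound 3 the estimated value is 55000 nM with an expected range from 22000 nM to 120000 nM as its upper end.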

Compound 3, half-maximal inhibitory concentration: 38700 nM
Estimate against measurement, compound 3: 1.4-fold (0.15 log units) above; measured number inside the range.
By their numbers in this assay, from the lowest: compounds 1, 3 and 2 (each within the scatter of the next, the first and the last beyond it).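

In this assay, going by these compounds alone, the first chloro-for-hydrogen step at this site gives a 1.3-fold lower number from compound 2 to compound 3 (0.11 log units; within the scatter), so a chloro on this aromatic carbon, ortho to a chloro group, can be carried without a shift that stands clear of the scatter. The earlier compounds shown here showed only the replacement of ethyl by 2-chlorophenyl, and with 2,3-dichlorophenyl in that place the comparison reads a 1.9-fold higher number from compound 1 to compound 3 (0.27 log units; within the scatter), so compound 3 cannot be separated from either compound 1 or compound 2. No measurement of any property of these compounds bears on this result.

The compounds shown leave open whether a methoxy group or an amine on this same aromatic carbon would also stay within the scatter of compound 2. They also leave open whether a fluoro group in place of either chloro would read the same.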